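The compounds below may be only part of what the source reports. "The series", "measured", "known", "first", "only" and "open" are said of these compounds alone.

Compound 1 `CN(C)c1ccc(C=C2C(=O)N(c3ccc(Cl)cc3)N(c3ccc(Cl)cc3)C2=O)cc1`: > 128000 nM (a limit)
Compound 2 `COc1ccccc1C=C1C(=O)N(c2ccc(Cl)cc2)N(c2ccc(Cl)cc2)C1=O`: 25800 nM

Among the compounds with values here, in a functional assay on SMMC-7721 cells (Homo sapiens) for cytotoxicity, read by MTT assay, with a stated time of 72 h (a lower number here means a stronger inhibitor, a higher number a weaker inhibitor), compound 2 gives 25800 nM, the only true number so far. Compound 1 gives > 128000 nM, which is a limit. Compound 3 `O=C1C(=Cc2c[nH]c3ccccc23)C(=O)N(c2ccc(Cl)cc2)N1c1ccc(Cl)cc1` changes the same place again: 1H-indol-3-yl in place of 2-methoxyphenyl on a double-bonded chain carbon bound to a double-bonded ring carbon. Within the data shown here, the one measured step at this place is an at least 4.9-fold lower number from compound 1 to compound 2 (0.69 log units; beyond the scatter), which lies beyond the scatter. It shows that this place can move the value, but not which way a new group will go, so only a small to modest step is expected, slightly toward a lower number. The expected change is a 1.3-fold lower number from compound 2 to compound 3 (0.11 log units; within the scatter). For compound 3 the estimate is 20000 nM, within an expected range of 6000 nM to 70000 nM.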

Compound 3, half-maximal inhibitory concentration: 19600 nM
Beside the measured number, compound 3's estimate is 1.0-fold (0.01 log units) above it; the measured number falls inside the stated range.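

In this assay, replacing the hydrogen-bond acceptor of 2-methoxyphenyl with the hydrogen-bond donor of 1H-indol-3-yl gives a 1.3-fold lower number from compound 2 to compound 3 (0.12 log units; within the scatter), so these two groups cannot be told apart at this place. Replacing 4-(dimethylamino)phenyl with 1H-indol-3-yl gives an at least 6.5-fold lower number from compound 1 to compound 3 (0.81 log units; beyond the scatter), so the gain over compound 1 now appears with two different groups. That step starts from a limit: the limit of > 128000 nM in this assay, at which 1 of the 3 values shown sits.

The compounds shown leave open how a carboxylic acid or a simple aminoalkyl chain would behave at this place. They also leave open whether any group here can give a much stronger inhibitor.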